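Amino for chloro on the shared core: two benzyl series

The source may hold more compounds than are shown below. What is called first, only, known or untested is meant among the compounds shown, and "the series" means these compounds.

Compound 1 `ClCc1ccccc1Cn1cnc2c(Cl)nc(Cl)nc21` and compound 2 `ClCc1cccc(Cn2cnc3c(Cl)nc(Cl)nc32)c1` share their atoms but join them differently; the difference between the two cores is not broken down here. In a functional assay on NCI-H226 cells (Homo sapiens) for cytotoxicity, read by sulforhodamine B assay, with a stated time of 48 h (a lower number here means a stronger inhibitor of growth, a higher number a weaker inhibitor of growth), compound 1 gives 1730 nM, compound 2 gives 3230 nM and compound 3 `Nc1nc(Cl)c2ncn(Cc3ccccc3CCl)c2n1` gives 2630 nM. From compound 1 to compound 3 the change is amino in place of chloro on an aromatic carbon, and the step is a 1.5-fold higher number from compound 1 to compound 3 (0.18 log units; within the scatter). Compound 4 `Nc1nc(Cl)c2ncn(Cc3cccc(CCl)c3)c2n1` is not yet measured; it stands to compound 2 as compound 3 stands to compound 1, the change being (amino in place of chloro on an aromatic carbon), the same change at the same place. Because compound 3 moved by a 1.5-fold higher number from compound 1 to compound 3 (0.18 log units; within the scatter), the expected step for compound 4 is a 1.5-fold higher number from compound 2 to compound 4 (0.17 log units; within the scatter), with nothing else to rest on. For compound 4 the estimate in this assay is 4800 nM, expected to fall from 2400 nM to 9600 nM.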

Compound 4, concentration for 50% growth inhibition: 10700 nM
Beside the measured number, compound 4's estimate is 2.2-fold (0.35 log units) below it; the whole stated range lies below it.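

In this assay, amino in place of chloro on an aromatic carbon gives a 3.3-fold higher number from compound 2 to compound 4 (0.52 log units; beyond the scatter), a modest step that lies beyond the scatter. Set beside the step on the other core, it does not differ by more than two such steps can scatter: the same change on two cores in this assay, a 1.5-fold higher number (0.18 log units; within the scatter) from compound 1 to compound 3 and a 3.3-fold higher number (0.52 log units; beyond the scatter) from compound 2 to compound 4, 2.2-fold (0.34 log units) apart, within the scatter of two such steps. These two pairs therefore show no clear dependence on the core, but they do not show that the step has a constant size, and they cannot establish how it would behave on any further core.

The compounds shown carry only chloro or amino at this carbon. As far as these compounds go, whether a methylamino or methoxy group there would fit the same picture remains open, as does the effect of a hydroxymethyl group in place of chloromethyl.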